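Methoxy in place of hydrogen: estimating compound 3

This account rests on a few compounds, and the source may have more. Where it says the series, first, only, none or still open, it means among the compounds named here.

Measured so far:
compound 1 `C[C@H](Nc1cc(F)c(S(=O)(=O)Nc2cscn2)cc1Cl)c1ccccc1F` — in an assay on HEK293 cells for inhibition of SCN8A/SCN1B (Homo sapiens), read by patch clamp, with a stated time of 20 min (a higher number here means a weaker inhibitor, a lower number a stronger inhibitor), compound 1 gives 410 nM
compound 2 `O=S(=O)(Nc1cscn1)c1cc(Cl)c(NCc2cc(F)ccc2F)cc1F` — in this assay compound 2 gives 450 nM

Compound 1 stands at one of two numbers, with compound 2 within the scatter of it; the step of a 1.1-fold higher number from compound 1 to compound 2 (0.04 log units; within the scatter) gives no order between them. Compound 3 `COc1ccc(F)c([C@H](C)Nc2cc(F)c(S(=O)(=O)Nc3cscn3)cc2Cl)c1` differs from compound 1 by methoxy in place of hydrogen on an aromatic carbon. Within the data shown here, no measured step touches this position. Among the measured compounds shown here, the only step available, a 1.1-fold higher number from compound 1 to compound 2 (0.04 log units; within the scatter), exchanges the whole group on the nitrogen on the aromatic ring and stays within the scatter, so the number appears little moved by changes in that part. For compound 3 a step of a 1.0-fold lower number from compound 1 to compound 3 (0.01 log units; within the scatter) is therefore expected, none beyond the scatter. Compound 3 is estimated at 400 nM, ranging from 150 nM to 1100 nM.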

Compound 3, half-maximal inhibitory concentration: 110 nM
Compound 3: middle estimate off by 3.6-fold (0.56 log units), on the high side; measured number outside the range, below it.
By their numbers in this assay, from the lowest: compound 3; then compounds 1 and 2 (each within the scatter of the next).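

In this assay the methoxy group brings a 3.7-fold lower number from compound 1 to compound 3 (0.57 log units; beyond the scatter) and so shows that this aromatic carbon, para to the fluoro group, is a place where the number responds to substitution. The earlier step between compounds 1 and 2 exchanged the whole group on the nitrogen and gave no reading of this position. No evidence here bears on the reason for the shift. Going by these compounds, whether the step belongs to methoxy itself remains open, as hydroxy, ethoxy or an amine on this carbon would test that. Whether it carries over to the benzyl group of compound 2 is also unsettled.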